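Swapping Chloro for Fluoro on a Chalcone Side Ring

This account rests on a few compounds, and the source may have more. Where it says the series, first, only, none or still open, it means among the compounds named here.

Among the measured compounds shown here, compound 2 `O=C(/C=C/c1ccc(Cl)cc1)c1ccccc1` is the stronger of the two compounds measured so far in a functional assay on HCT-116 cells (Homo sapiens) for antiproliferative activity, read by sulforhodamine B assay, with a stated time of 3 days, tested at 25 uM; on this read-out higher numbers stand for a stronger effect at the one concentration tested and lower numbers for a weaker effect: compound 2 gives 97.5%, the highest of the two numbers available. The nearest measured compound, compound 1 `Cc1ccc(COc2ccc(C(=O)/C=C/c3ccccc3)cc2)cc1`, gives 4% in this assay, a gap that lies well beyond the usual scatter of repeated measurements. Compound 3 `O=C(/C=C/c1ccc(F)cc1)c1ccccc1` has not yet been measured. It differs from compound 2 in one place: fluoro in place of chloro on an aromatic carbon. For the measured compounds named here, no measured pair shows this particular exchange, so its effect cannot be read from the numbers at hand. Exchanging one halogen for another on an aromatic carbon is expected to move the read-out only a little, most likely slightly downward or not beyond the scatter; the step of a number 12.5 percentage points lower from compound 2 to compound 3 (beyond the scatter) is the estimate. Compound 3 is therefore expected to give 85% in this assay, with a range from 55% to 98%.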

Compound 3, a percentage reported as inhibition, at one concentration (the size of the read-out at that concentration, not a potency): 86.8%
Beside the measured number, compound 3's estimate is 1.8 percentage points below it, and the stated range covers the measured number.
By their numbers in this assay, from the lowest: compound 1; then compound 3; then compound 2.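

In this assay the exchange of chloro for fluoro, on an aromatic carbon para to a large group, gives a number 10.7 percentage points lower from compound 2 to compound 3 (beyond the scatter) and offers the first direct view of what one changed atom does at this place. The choice of halogen here does register in the read-out, yet the step is modest, and compound 3 keeps most of the effect seen with compound 2. Nothing available explains what lies behind this step. The compounds shown leave open how an amine, a carboxylic acid or a longer chain would behave on this same carbon, and what plain hydrogen there would give. A read-out at a single concentration also leaves open how the potencies of these two halogen compounds compare.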